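This account rests on a few compounds, and the source may have more. Where it says the series, first, only, none or still open, it means among the compounds named here.

Compound 1, `COc1ccccc1N1CCN(CCCCC(=O)NCc2ccccc2-c2cccc(F)c2)CC1`, gives 34.7 nM in an assay on CHO-K1 cells for displacement of a labelled ligand from 5-hydroxytryptamine receptor 7 (Homo sapiens), read by scintillation counting; on this read-out higher numbers stand for weaker inhibition and lower numbers for stronger inhibition.
Compound 2, `COc1ccccc1N1CCN(CCCCC(=O)NCc2ccccc2-c2ccccc2F)CC1`, gives 36.5 nM in this assay.

Only these two compounds have been measured, and the difference between them, a 1.1-fold higher number from compound 1 to compound 2 (0.02 log units; within the scatter), lies within the scatter, so compound 2 cannot be set apart from compound 1 on these numbers; the two are indistinguishable in this assay.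

Compound 3, `COc1ccccc1N1CCN(CCCCC(=O)NCc2ccccc2-c2ccc(C)cc2)CC1`, differs from compound 2 in one place: 4-methylphenyl in place of 2-fluorophenyl on an aromatic carbon. Going by the values given here, the single measured step concerned only the position of a fluorine on the same ring and produced no shift beyond the scatter. Among the compounds with values here, no measured step exchanges the fluorine for a methyl group or moves a substituent to the 4-position of that ring, so nothing in the data speaks directly to this change. Within the data shown here, with the one available step silent and small, a step in this assay of no more than the usual scatter is expected, in no particular direction, and the expected move is a 1.0-fold lower number from compound 2 to compound 3 (0.01 log units; within the scatter). Compound 3 is therefore estimated at 36 nM, with a range from 14 nM to 90 nM.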

Compound 3, inhibition constant: 66.1 nM
Beside the measured number, compound 3's estimate is 1.8-fold (0.26 log units) below it; the range from low to high includes it.
By their numbers in this assay, from the lowest: compounds 1, 2 and 3 (each within the scatter of the next).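

Until now the data spoke only to where a fluorine sits on this ring, whereas compound 3 replaces the fluorinated ring with 4-methylphenyl, a group of carbon only, on the same aromatic carbon, ortho to a large group. The exchange for 2-fluorophenyl gives a 1.8-fold higher number from compound 2 to compound 3 (0.26 log units; within the scatter) in this assay and the exchange for 3-fluorophenyl gives a 1.9-fold higher number from compound 1 to compound 3 (0.28 log units; within the scatter) so neither step sets compound 3 apart, and this position has now taken a methyl-bearing ring as well as two fluorinated rings without a step beyond the scatter. Nothing else is available here that could account for these numbers.

The three compounds change the substituent and its place on the ring together, so a 4-fluorophenyl or a 2-methylphenyl group would be needed to separate the effect of the methyl from that of its position. On these data alone, it also remains open whether a group of another kind on this ring, such as an amine or a carboxylic acid, or a longer chain in place of the methyl, would give a step beyond the scatter.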